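The source may report more compounds than this note shows. Statements on the series, on what has been measured and on what is new or still open speak of the compounds shown alone.

Three compounds share one core and differ at two places. Compound 1 `COc1cc2c(Oc3ccc(NC(=O)c4cc(-c5ccccc5F)ccn4)cc3F)ccnc2cc1OCCCN1CCCCC1` gives 320 nM in a functional assay on HT-29 cells (Homo sapiens) for cytotoxicity, read by MTT assay, with a stated time of 72 h; on this read-out higher numbers stand for weaker inhibition and lower numbers for stronger inhibition. Compound 2 `COc1cc2c(Oc3ccc(NC(=O)c4cc(-c5ccccc5C)ccn4)cc3F)ccnc2cc1OCCCN1CCN(C)CC1` gives 180 nM in this assay, and compound 3 `COc1cc2c(Oc3ccc(NC(=O)c4cc(-c5ccccc5C)ccn4)cc3F)ccnc2cc1OCCCN1CCCC1` gives 1150 nM in this assay, the highest of the three numbers. Among the measured compounds shown here, the only single-point step measured is a 6.4-fold higher number from compound 2 to compound 3 (0.81 log units; beyond the scatter), a change at the end of the chain. Compound 4 `COc1ccc(-c2ccnc(C(=O)Nc3ccc(Oc4ccnc5cc(OCCCN6CCCC6)c(OC)cc45)c(F)c3)c2)c(OC)c1` differs from compound 3 at another place: 2,4-dimethoxyphenyl in place of 2-methylphenyl on an aromatic carbon. For the measured compounds named here, no measured step touches that position; compounds 1 and 2 differ there but also at the chain end, so they show only their two values. The expected step is therefore uncertain, and a 1.2-fold lower number from compound 3 to compound 4 (0.06 log units; within the scatter) is estimated as no change beyond the scatter. Compound 4 is expected to give 1000 nM, estimated between 350 nM and 3000 nM.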

Compound 4, half-maximal inhibitory concentration: 630 nM
For compound 4 the middle estimate is 1.6-fold (0.20 log units) above the measured one, and the stated range covers the measured number.
By their numbers in this assay, from the lowest: compounds 2, 1, 4 and 3 (each within the scatter of the next, the first and the last beyond it).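

Among the compounds shown here, the first measured step at this position is a 1.8-fold lower number from compound 3 to compound 4 (0.26 log units; within the scatter) in this assay. On this aromatic carbon, opposite the ring nitrogen, 2,4-dimethoxyphenyl can therefore replace 2-methylphenyl without a change beyond the scatter, even though it adds heavy atoms and 2 hydrogen-bond acceptors, at least with pyrrolidin-1-yl at the chain end. Nothing available explains this result. On these data alone, whether the same swap holds with 4-methylpiperazin-1-yl at the chain end remains open. So does whether an amine or a carboxylic acid on this phenyl ring would move the number beyond the scatter.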